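Swapping 4-(trifluoromethyl)phenyl for 3-methylphenyl on the carbonyl carbon

A few compounds are considered here, and "the series" means these few. Any claim that something is new, unique, unknown or untested is made for them only; others in the source may bear on it.

In a functional assay on a cell-free system (Platelet, plasma, Homo sapiens) for inhibition (on this read-out higher numbers stand for weaker inhibition and lower numbers for stronger inhibition), compound 3 `O=C(O)COC1CCN(CCN(C(=O)c2ccc(C(F)(F)F)cc2)c2ccc(Cl)cc2)CC1` stands at > 10000 nM, which is a limit of the assay and not a number. Compound 4 `Cc1cccc(C(=O)N(CCN2CCC(OCC(=O)O)CC2)c2ccc(Cl)cc2)c1` carries 3-methylphenyl in place of 4-(trifluoromethyl)phenyl on a carbonyl carbon. Compound 2 `O=C(O)COC1CCN(CCN(C(=O)c2ccc(Cl)cc2)c2ccc(Cl)cc2)CC1` gives 1500 nM. Within the data shown here, the one measured step touching this group, trifluoromethyl in place of chloro on an aromatic carbon, gives an at least 6.6-fold higher number from compound 2 to compound 3 (0.82 log units; beyond the scatter). Compound 1 `Cc1ccc(N(CCN2CCC(OCC(=O)O)CC2)C(=O)c2cccc(C)c2)cc1` has the same 3-methylphenyl on its carbonyl carbon and gives 160 nM, and the expectation rests mainly on that value. The expected change, towards stronger inhibition and well beyond the scatter, is an at least 50-fold lower number from compound 3 to compound 4 (1.69 log units; beyond the scatter). For compound 4 the estimated value is 200 nM, with an expected range of 50 nM to 800 nM.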

Compound 4, half-maximal inhibitory concentration: 310 nM
For compound 4 the middle estimate is 1.6-fold (0.19 log units) below the measured one; low and high end bracket the measured number.
By their numbers in this assay, from the lowest: compounds 1 and 4 (each within the scatter of the next); then compound 2. At a limit, above all of these: compound 3.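

In this assay compound 3 holds only a limit of the assay, not a number: the limit of > 10000 nM in this assay, at which 1 of the 4 values shown sits. On the carbonyl carbon, 3-methylphenyl in place of 4-(trifluoromethyl)phenyl gives an at least 32-fold lower number from compound 3 to compound 4 (1.50 log units; beyond the scatter), and in place of 4-chlorophenyl it gives a 4.8-fold lower number from compound 2 to compound 4 (0.68 log units; beyond the scatter), so the gain also stands between two measured numbers. With 3-methylphenyl on the carbonyl carbon, chloro in place of methyl on an aromatic carbon gives a 1.9-fold higher number from compound 1 to compound 4 (0.29 log units; within the scatter), so that swap shows no readable change. The compounds shown leave open whether the gain belongs to the methyl group or to where it sits: 4-methylphenyl or 3-chlorophenyl on the carbonyl carbon would separate the two.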